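Methyl for methoxy on the fused ring: compound 4

The compounds below may be only part of what the source reports. "The series", "measured", "known", "first", "only" and "open" are said of these compounds alone.

Measured so far:
compound 1 `Cc1ccc2nc(NC(=O)c3cn(-c4ccccc4)nc3-c3ccc(F)cc3)sc2c1`, > 50000 nM
compound 2 `COc1ccc(-c2nn(-c3ccccc3)cc2C(=O)Nc2nc3ccc(F)cc3s2)cc1`, 8990 nM
compound 3 `COc1ccc(-c2nn(-c3ccccc3)cc2C(=O)Nc2nc3ccc(OC)cc3s2)cc1`, 5890 nM

In a functional assay on U-87MG ATCC cells for cytotoxicity against U-87 MG (Homo sapiens), read by MTT assay, with a stated time of 72 h (on this read-out lower numbers stand for stronger inhibition and higher numbers for weaker inhibition), compound 1 gives > 50000 nM, which is a limit of the assay and not a number, as the limit of > 50000 nM in this assay, at which 1 of the 3 values shown sits, states. In this assay compound 2 gives 8990 nM. Compound 3 gives 5890 nM in this assay, and its nearest neighbour is compound 2, with a 1.5-fold lower number from compound 2 to compound 3 (0.18 log units; within the scatter), so the two sit within the scatter of each other.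

Compound 4 `COc1ccc(-c2nn(-c3ccccc3)cc2C(=O)Nc2nc3ccc(C)cc3s2)cc1` differs from compound 3 by methyl in place of methoxy on an aromatic carbon, read one bond further out as 6-methoxy-1,3-benzothiazol-2-yl to 6-methyl-1,3-benzothiazol-2-yl. Among the compounds with values here, the only measured step at that part of the shared core is fluoro to methoxy, a 1.5-fold lower number from compound 2 to compound 3 (0.18 log units; within the scatter), within the scatter. Compound 1 also carries a methyl on its fused ring system, but its other ring differs as well, and it gives only a limit. Within the data shown here, no measured step therefore fixes this change. Compound 4 is expected to give 12000 nM in this assay, within 5000 nM to 40000 nM, a step of a 2.0-fold higher number from compound 3 to compound 4 (0.31 log units; beyond the scatter) that may exceed the scatter toward a higher number.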

Compound 4, half-maximal inhibitory concentration: > 50000 nM
Compound 4: no number, only a limit; the forecaster's own chance of this, stated with the estimate: 25%; middle value at least 4.1-fold (0.61 log units) away from the limit.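

In this assay this position on the fused ring now shows a change beyond the scatter: methyl in place of methoxy gives an at least 8.4-fold higher number from compound 3 to compound 4 (0.92 log units; beyond the scatter), and methyl in place of fluoro gives an at least 5.5-fold higher number from compound 2 to compound 4 (0.74 log units; beyond the scatter), whereas the earlier fluoro to methoxy change gave a 1.5-fold lower number from compound 2 to compound 3 (0.18 log units; within the scatter). Compound 4 gives a limit of the assay and not a number, so both new steps fix only a smallest size. The step from compound 1 to compound 4 cannot be read, because both compounds sit at the same limit of the assay: the limit of > 50000 nM in this assay, at which 2 of the 4 values shown sit.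

How far compound 4 lies from compound 3 remains undetermined. Also open, on these data alone, is how the read-out responds at this position to groups beyond fluoro, methoxy and methyl, such as an amine, a carboxylic acid or a longer ether chain.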